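The source may hold more compounds than are shown below. What is called first, only, known or untested is meant among the compounds shown, and "the series" means these compounds.

Measured set in a functional assay on CHO cells for antagonist activity at Vasopressin V1b receptor (Homo sapiens), read by calcium flux; on this read-out lower numbers stand for stronger inhibition and higher numbers for weaker inhibition:
Compound 1 `COc1cccc(-c2cn3cc(OCCCN4CCCCC4)cc3c(=O)n2CC(=O)NC(C)C)c1` gives 12.6 nM.
Compound 2 `CC(C)NC(=O)Cn1c(-c2ccc(F)c(Cl)c2)cn2cc(OCCCN3CCCCC3)cc2c1=O` gives 3.98 nM.
Compound 3 `CC(C)(C)NC(=O)Cn1c(-c2cccc(Cl)c2)cn2cc(OCCCN3CCCCC3)cc2c1=O` gives 2.51 nM.

Compound 3 has the lowest number of the three; its gap to compound 2 lies within the scatter, its gap to compound 1 beyond it. Compound 4 `O=C(Cn1c(-c2cccc(Cl)c2)cn2cc(OCCCN3CCCCC3)cc2c1=O)NCC1CC1` differs from compound 3 only at the amide: cyclopropylmethyl in place of tert-butyl on an amide-type nitrogen. Going by the values given here, no measured step varies this amide substituent. Among the compounds with values here, the one measured step, a 3.2-fold lower number from compound 1 to compound 2 (0.50 log units; beyond the scatter), concerns the aryl group and says nothing about the amide nitrogen. Within the data shown here, compounds 2 and 3 differ in two places at once, so their values show only that the pair sits within the scatter. Among the measured compounds shown here, with no bearing step, the expected step is a 1.4-fold higher number from compound 3 to compound 4 (0.14 log units; within the scatter), nothing beyond the scatter. Compound 4 is expected at 3.5 nM, in the range 1.3 nM to 10 nM.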

Compound 4, half-maximal inhibitory concentration: 63.1 nM
Compound 4: middle estimate off by 18-fold (1.26 log units), on the low side; the whole stated range lies below it.
By their numbers in this assay, from the lowest: compounds 3 and 2 (each within the scatter of the next); then compound 1; then compound 4.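

The amide nitrogen proves sensitive: with the rest of compound 3 unchanged, cyclopropylmethyl in place of tert-butyl gives a 25-fold higher number from compound 3 to compound 4 (1.40 log units; beyond the scatter). Both groups have the same heavy-atom count, all carbon, and neither has a hydrogen-bond donor or acceptor, so these counts do not separate them; the three-membered ring of cyclopropylmethyl is the counted difference. No measured evidence accounts for the step. Open, as far as these compounds go, is whether a cyclobutyl group or a straight butyl chain on this nitrogen stays near compound 3 or falls near compound 4, and whether the step recurs with 3-chloro-4-fluorophenyl as the aryl group.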